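The source may hold more compounds than are shown below. What is called first, only, known or untested is meant among the compounds shown, and "the series" means these compounds.

Measured so far in an ADME assay on L929 cells (Mus musculus) for cytotoxicity, read by resazurin assay, with a stated time of 48 h; a lower number here means that less compound is tolerated, a higher number that more compound is tolerated:
- Compound 1 `COC(=O)COc1c2cc([N+](=O)[O-])ccc2nn1Cc1ccccc1`: > 256000 nM
- Compound 2 `O=[N+]([O-])c1ccc2nn(Cc3ccccc3)c(OCCO)c2c1`: > 256000 nM

Compound 2 gives > 256000 nM, which is a limit and not a number. Its position in the series is the limit of > 256000 nM in this assay, at which 2 of the 2 values shown sit. Compound 3 `COCCOc1c2cc([N+](=O)[O-])ccc2nn1Cc1ccccc1` is not yet measured. It differs from compound 2 by methyl in place of hydrogen on an oxygen on a saturated carbon, so 2-hydroxyethyl becomes 2-methoxyethyl.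

Within the data shown here, only one measured step bears on this change, a step that the two limits leave unreadable from compound 1 to compound 2, with hydroxymethyl in place of methoxycarbonyl. Its size cannot be read, so it sets no scale. Both compound 1 and compound 2 end in a limit, so no change is expected in this assay beyond the scatter. The expected step is a step that the limit leaves unreadable from compound 2 to compound 3. The estimate for compound 3 is 280000 nM, with an expected range of 130000 nM to 512000 nM.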

Compound 3, concentration lethal to 50% of the cells: > 256000 nM
Compound 3: no number, only a limit; the forecaster's own chance of this, stated with the estimate: 85%; the middle value does not contradict the limit.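

In this assay, no step among compound 1, compound 2 and compound 3 can be read, because all three stand at the same limit: the limit of > 256000 nM in this assay, at which 3 of the 3 values shown sit.

The compounds shown leave open whether any change to the shared core would give a measurable lethal concentration in this assay.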